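From acetyl to propylcarbonyl in an antiproliferative series

The source may hold more compounds than are shown below. What is called first, only, known or untested is meant among the compounds shown, and "the series" means these compounds.

Measured in a functional assay on PC-3 cells (Homo sapiens) for antiproliferative activity, read by MTT assay, with a stated time of 72 h; on this read-out higher numbers stand for weaker inhibition and lower numbers for stronger inhibition
- Compound 1 `COc1ccc(NC(=S)Nc2nc(C(=O)NCc3ccccc3)cs2)cc1` gives 39300 nM
- Compound 2 `CCOC(=O)c1csc2nc(CN3CCN(C)CC3)c(-c3ccc(Br)cc3)n12` gives 85000 nM
- Compound 3 `CC(=O)NNC(=O)c1csc2ncc(-c3ccc(C)cc3)n12` gives 92700 nM

Compound 3 (92700 nM) and compound 2 (85000 nM) lie within the usual scatter of each other. Compound 1 (39300 nM) gives a lower number, and its gap to compound 3 lies beyond that scatter. Compound 3 therefore stands with compound 2 at the upper end of these numbers, on the side of weaker inhibition.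

The next compound to be tested is compound 4 `CCCC(=O)NNC(=O)c1csc2ncc(-c3ccc(C)cc3)n12` and it keeps the core of compound 3. The change is ethyl in place of hydrogen on a saturated chain carbon bound to a carbonyl carbon and it turns the acetyl into a propylcarbonyl. Going by the values given here, no two measured compounds differ in one place only, so the data offer no direct precedent for this change in this assay and any forecast stays cautious. The expectation starts from compound 3 (92700 nM) and allows only a small move towards a lower number. The expected size is a 1.3-fold lower number from compound 3 to compound 4 (0.12 log units; within the scatter) and an estimated step of that size would stay within the scatter. For compound 4 the estimate is 70000 nM with an expected range from 30000 nM to 150000 nM in this measurement.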

Compound 4, half-maximal inhibitory concentration: 53500 nM
Estimate against measurement, compound 4: 1.3-fold (0.12 log units) above; the measured number falls inside the stated range.
By their numbers in this assay, from the lowest: compounds 1, 4, 2 and 3 (each within the scatter of the next, the first and the last beyond it).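

Going by these compounds alone, the result supplies the first step that changes one place only, and in this assay it reads a 1.7-fold lower number from compound 3 to compound 4 (0.24 log units; within the scatter). Ethyl in place of hydrogen on a saturated chain carbon bound to a carbonyl carbon, which turns the acetyl into a propylcarbonyl, therefore adds two carbon atoms at this place without a shift that can be told apart from the spread of repeated measurements, so this single step sets no direction for chain length here. No supporting information on this result is available to account for the outcome of the change.

The compounds shown leave open whether a longer chain, such as pentyl, or a chain ending in an amine or a carboxylic acid at this same place would give a step beyond the scatter, since the acetyl and propylcarbonyl pair covers only a short stretch of what the position could carry. They also leave open whether the same change from methyl to propyl would read the same way on a different core, or in any assay other than this assay.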